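The compounds below may be only part of what the source reports. "The series", "measured", "known", "first", "only" and "open" are said of these compounds alone.

Compound 2 `O=C(O)c1cccc(CCCCCC(=O)N2CCOC2=O)c1` is one of two measured members of this small series; the other is compound 1 `O=C(CCCCCc1cccc(CO)c1)N1CCOC1=O`. In an assay on HEK293 cells for inhibition of N-acylethanolamine-hydrolyzing acid amidase (Rattus norvegicus), read by LC-MS, with a stated time of 30 min (a lower number here means a stronger inhibitor, a higher number a weaker inhibitor), compound 2 gives only a limit of the assay, > 20000 nM. In this assay compound 1 likewise gives only a limit, > 20000 nM. The step that the two limits leave unreadable from compound 1 to compound 2 therefore cannot be read, because both values sit at the limit of > 20000 nM in this assay, at which 2 of the 2 values shown sit. Compound 3 `O=C(CCCCCc1cccc(C(F)(F)F)c1)N1CCOC1=O` differs from compound 2 in a single place: trifluoromethyl in place of carboxy on an aromatic carbon. Among the compounds with values here, the one measured step is unreadable, so it offers no guide to the size or direction of the change expected in this assay when trifluoromethyl stands where carboxy stood. With both measured values at the limit, compound 3 is expected to remain near it, so the step of a number no higher from compound 2 to compound 3 (the limit leaves the size open) is estimated to be small. Compound 3 is expected at about 20000 nM, within a range from 5000 nM to 80000 nM, and most likely will again be reported only as a limit.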

Compound 3, half-maximal inhibitory concentration: 58 nM
Estimate against measurement, compound 3: 340-fold (2.54 log units) above, and the stated range ends above it.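

In this assay, the group on this aromatic carbon, meta to a large group, proves able to move the number a long way: trifluoromethyl in place of carboxy gives an at least 340-fold lower number from compound 2 to compound 3 (2.53 log units; beyond the scatter), and trifluoromethyl in place of hydroxymethyl gives an at least 340-fold lower number from compound 1 to compound 3 (2.53 log units; beyond the scatter). As far as these compounds go, both steps point the same way, towards a stronger inhibitor, so this position is sensitive to the group it carries, and each step's full size remains unknown. The earlier pair could not show this because both of its compounds stood at the same value: the limit of > 20000 nM in this assay, at which 2 of the 3 values shown sit.

From the compounds shown here alone, what a chlorine, a methyl or a nitrile on this same aromatic carbon would give remains open. So does what compound 3 would give with a shorter or longer chain, or with trifluoromethyl elsewhere on the six-membered aromatic ring.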